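The compounds below may be only part of what the source reports. "The series", "measured", "known", "first", "only" and "open" are said of these compounds alone.

Compound 1, whose structure is `COc1cc(OC)c(C(=O)/C=C/c2ccccc2OC)c(OC)c1`, gives 8200 nM in an ADME assay on cells (Fibroblast, Homo sapiens) for cytotoxicity, with a stated time of 48 h; a lower number here means a stronger inhibitor, a higher number a weaker inhibitor. Compound 2, with the structure `COc1cccc(/C=C/C(=O)c2c(OC)cc(OC)cc2OC)c1`, is recorded in this assay only as a limit, > 20000 nM. Compound 3, with the structure `COc1cc(O)c(C(=O)/C=C/c2ccccc2OC)c(OC)c1`, is likewise recorded only as a limit, > 20000 nM. The difference between compound 1 and compound 2 is 3-methoxyphenyl in place of 2-methoxyphenyl on a double-bonded chain carbon bound to a double-bonded chain carbon, and it carries the step of an at least 2.4-fold higher number from compound 1 to compound 2 (0.38 log units; beyond the scatter). The difference between compound 1 and compound 3 is hydrogen in place of methyl on an oxygen on an aromatic ring, and it carries the step of an at least 2.4-fold higher number from compound 1 to compound 3 (0.38 log units; beyond the scatter). Compound 4, with the structure `COc1cccc(/C=C/C(=O)c2c(O)cc(OC)cc2OC)c1`, has not yet been measured in this assay; it differs from compound 2 by hydrogen in place of methyl on an oxygen on an aromatic ring, the same change that separates compound 3 from compound 1, made on the core of compound 2. Two of the three values shown already sit at the limit (the limit of > 20000 nM in this assay, at which 2 of the 3 values shown sit), so the step from compound 2 to compound 4 is expected to read as a step that the limit leaves unreadable from compound 2 to compound 4. Compound 4 is therefore estimated at 30000 nM, between 15000 nM and 80000 nM.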

Compound 4, half-maximal inhibitory concentration: > 20000 nM
Compound 4 was reported as a limit; the forecaster's own chance of this, stated with the estimate: 80%; the middle value is on the limit's open side.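

Compound 4 is recorded in this assay only as a limit, > 20000 nM, and compound 2 is a limit too, so no step can be read between these two compounds: the limit of > 20000 nM in this assay, at which 3 of the 4 values shown sit.

The compounds shown leave open how far the values of compound 2 and compound 4 lie beyond the limit, and whether methoxy to hydroxy changes the number on the core of compound 2.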